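Swapping the tetrazole on the shared core

The source may report more compounds than this note shows. Statements on the series, on what has been measured and on what is new or still open speak of the compounds shown alone.

Measured so far in a functional assay (blood) for inhibition, with Homo sapiens as the target; a lower number here means a stronger inhibitor, a higher number a weaker inhibitor:
- Compound 1 `CC(O)c1cc(-c2ccccc2)c2ccc(OCc3cccc(C4(O)CCOCC4)c3)cc2c1`: 675 nM
- Compound 2 `N#Cc1cc(-c2ccccc2)c2ccc(OCc3cccc(C4(O)CCOCC4)c3)cc2c1`: 100 nM
- Compound 3 `OC1(c2cccc(COc3ccc4c(-c5ccccc5)cc(-c5nn[nH]n5)cc4c3)c2)CCOCC1`: > 3000 nM

Compound 3 gives > 3000 nM, which is a limit of the assay and not a number. For the measured compounds named here, it is the one compound at the limit of > 3000 nM in this assay, at which 1 of the 3 values shown sits.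

Compound 4 `Cn1nnnc1-c1cc(-c2ccccc2)c2ccc(OCc3cccc(C4(O)CCOCC4)c3)cc2c1` has 1-methyl-1H-tetrazol-5-yl in place of 2H-tetrazol-5-yl on an aromatic carbon. This exact swap has not been measured, so the nearest evidence comes from other groups on that same carbon. With 2H-tetrazol-5-yl arriving, the record shows an at least 4.4-fold higher number from compound 1 to compound 3 (0.64 log units; beyond the scatter) and an at least 30-fold higher number from compound 2 to compound 3 (1.47 log units; beyond the scatter). Both steps are beyond the scatter, and they suggest that this particular group is what holds compound 3 at its limit. Compound 4 loses that group, so a clear move towards a lower number is expected in this assay, though the new group is itself a tetrazole and the recovery may be partial. The expected change is an at least 12-fold lower number from compound 3 to compound 4 (1.07 log units; beyond the scatter).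

For compound 4 the estimated value is 250 nM, with an expected range from 70 nM to 900 nM.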

Compound 4, half-maximal inhibitory concentration: > 10000 nM
Compound 4: a limit, no number; the forecaster's own chance of this, stated with the estimate: 7%; middle value at least 40-fold (1.60 log units) from the limit.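

In this assay, compound 4 sits at a limit of the assay and not at a number: the limit of > 10000 nM in this assay, at which 1 of the 4 values shown sits.

Adding a methyl group to the tetrazole therefore brings no visible recovery, and the 1-methyl-1H-tetrazol-5-yl group gives an at least 100-fold higher number from compound 2 to compound 4 (2.00 log units; beyond the scatter) and an at least 14-fold higher number from compound 1 to compound 4 (1.17 log units; beyond the scatter). The earlier compounds shown here could not show this: taking away the hydrogen-bond donor of the 2H-tetrazol-5-yl group does not restore the level of compound 1 or compound 2, so in these compounds both tetrazoles on this carbon stay far weaker than the nitrile and the 1-hydroxyethyl group.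

On these data alone, the step between compound 3 and compound 4 cannot be read, as both values are limits, so the order of the two tetrazoles stays open. Also open, as far as these compounds go, is how a carboxylic acid or a primary amide on this carbon would compare with the nitrile of compound 2.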